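This account rests on a few compounds, and the source may have more. Where it says the series, first, only, none or still open, it means among the compounds named here.

Measured so far:
- compound 1, `O=C(CCCC1CCN(C(=O)CCc2ccccc2)CC1)c1ncco1`: 22 nM
- compound 2, `O=C(CCCC1CCN(S(=O)(=O)CCc2ccccc2)CC1)c1ncco1`: 6 nM

Of the compounds shown here, two have been measured in an assay on isolated protein for inhibition of Fatty-acid amide hydrolase 1 (Homo sapiens); on this read-out higher numbers stand for weaker inhibition and lower numbers for stronger inhibition. Compound 1 gives 22 nM, and compound 2 gives 6 nM. On these two numbers compound 1 stands at the higher end, meaning the weaker inhibition of the pair, and the gap between compound 1 and compound 2 lies beyond the usual scatter of this assay. The two compounds differ in the group on the ring nitrogen of the shared core; no computed difference is given for that pair, so only the two values themselves can be compared.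

The next compound, compound 3, is `CC(C)(C)CC(=O)N1CCC(CCCC(=O)c2ncco2)CC1`. It is derived from compound 1 by a single change: tert-butyl in place of benzyl on a saturated chain carbon bound to a carbonyl carbon. The aromatic ring that compound 1 carries at the end of the chain on the carbonyl is thus removed, and a branched saturated group of fewer heavy atoms takes its place. No measured step of this kind exists among the compounds shown, so the expectation rests on the structural change alone. Compound 3 is expected to inhibit less strongly than compound 1, with a step from compound 1 to compound 3 of a 2.7-fold higher number from compound 1 to compound 3 (0.44 log units; beyond the scatter), probably beyond the scatter. For compound 3 the estimated value in this assay is 60 nM, with a range from 15 nM to 250 nM.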

Compound 3, half-maximal inhibitory concentration: 90 nM
Beside the measured number, compound 3's estimate is 1.5-fold (0.18 log units) below it; measured number inside the range.
By their numbers in this assay, from the lowest: compound 2; then compound 1; then compound 3.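

In this assay, replacing benzyl with tert-butyl on a saturated chain carbon bound to a carbonyl carbon gives a 4.1-fold higher number from compound 1 to compound 3 (0.61 log units; beyond the scatter), so the group at this position affects the measured inhibition. The group that leaves has 7 heavy atoms and a six-membered aromatic ring, while the group that enters has 4 heavy atoms and no ring, and neither has hydrogen-bond donors or acceptors. Both the ring and the heavy-atom count change in this single step, so the step cannot show which of the two matters, and no measurement at hand explains the rise in the number.

A cyclohexyl group in place of benzyl would keep a six-membered ring while removing the aromatic one, but the compounds shown do not reveal whether its number would fall nearer compound 1 or compound 3. They also leave open whether tert-butyl in place of benzyl would shift the number in the same direction and by a similar amount on compound 2, which carries a different link to the ring nitrogen of the shared core.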